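Replacing the 4-(methylsulfanyl)phenyl group of compound 3

The source may hold more compounds than are shown below. What is called first, only, known or untested is meant among the compounds shown, and "the series" means these compounds.

Values measured in a functional assay on A549 cells (Homo sapiens) for inhibition, read by MTT assay, with a stated time of 48 h; on this read-out lower numbers stand for stronger inhibition and higher numbers for weaker inhibition:
- compound 1 `Cc1ccc(-c2nc3ccccn3c2Sc2ccccc2)cc1` gives 94300 nM
- compound 2 `COc1ccc(-c2nc3ccccn3c2Sc2ccccc2)cc1` gives 58400 nM
- compound 3 `CSc1ccc(-c2nc3ccccn3c2Sc2ccccc2)cc1` gives 13600 nM

Compound 3 has the lowest number of the three, with a 6.9-fold lower number from compound 1 to compound 3 (0.84 log units; beyond the scatter) and a 4.3-fold lower number from compound 2 to compound 3 (0.63 log units; beyond the scatter) both beyond the scatter, while a 1.6-fold lower number from compound 1 to compound 2 (0.21 log units; within the scatter) stays within it. In compound 4 `c1ccc(Sc2c(-c3ccsc3)nc3ccccn23)cc1` thiophen-3-yl stands in place of 4-(methylsulfanyl)phenyl on an aromatic carbon, and thiophen-3-yl in place of 4-(methylsulfanyl)phenyl on an aromatic carbon counts that change. Within the data shown here, the methylsulfanyl group is lost, so the two modest steps above are expected to be largely undone, although no thiophen-3-yl compound has been measured. The estimate is a 3.3-fold higher number from compound 3 to compound 4 (0.52 log units; beyond the scatter) in this assay as an expected upward step of similar size. The expected value of compound 4 is 45000 nM within an estimated range of 15000 nM to 130000 nM for now.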

Compound 4, half-maximal inhibitory concentration: 72900 nM
Beside the measured number, compound 4's estimate is 1.6-fold (0.21 log units) below it; the range from low to high includes it.
By their numbers in this assay, from the lowest: compound 3; then compounds 2, 4 and 1 (each within the scatter of the next).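

In this assay, a 5.4-fold higher number from compound 3 to compound 4 (0.73 log units; beyond the scatter) shows that at this position thiophen-3-yl does not keep the lower number held by the 4-(methylsulfanyl)phenyl group. With a 1.2-fold higher number from compound 2 to compound 4 (0.10 log units; within the scatter) and a 1.3-fold lower number from compound 1 to compound 4 (0.11 log units; within the scatter) both within the scatter, thiophen-3-yl cannot be told apart from 4-methoxyphenyl or 4-methylphenyl, so among these four compounds only compound 3 stands apart. No supporting data bear on the reason for these steps.

Open, as far as these compounds go, is whether a 4-(methylsulfonyl)phenyl or 4-aminophenyl group would match compound 3. Also open, from the compounds shown here alone, is whether a methylsulfanyl group on the thiophen-3-yl ring would lower the number of compound 4.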